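Sulfo to dimethylamino at the end of the chain

The source may hold more compounds than are shown below. What is called first, only, known or untested is meant among the compounds shown, and "the series" means these compounds.

Going by the values given here, in a functional assay for inhibition (a higher number here means a weaker inhibitor, a lower number a stronger inhibitor), compound 3 (`CC(C)(C)c1cc(-c2cc(=O)c3ccc(OCCCS(=O)(=O)O)cc3o2)cc(C(C)(C)C)c1O`) gives 500 nM, the lowest number among the three compounds measured so far. Compound 1 (`CC(C)(C)c1cc(-c2cc(=O)c3ccc(OCc4ccc5ccccc5n4)cc3o2)cc(C(C)(C)C)c1O`) gives 3000 nM. Compound 2 (`CCOC(=O)COc1ccc2c(=O)cc(-c3cc(C(C)(C)C)c(O)c(C(C)(C)C)c3)oc2c1`) gives 3000 nM.

The next compound is compound 4 (`CN(C)CCCOc1ccc2c(=O)cc(-c3cc(C(C)(C)C)c(O)c(C(C)(C)C)c3)oc2c1`), which shares its core with compound 3 and carries dimethylamino in place of sulfo on a saturated chain carbon, three bonds along the chain from an oxygen on an aromatic ring.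

Among the compounds with values here, no measured compound carries dimethylamino, so the evidence is indirect. Within the data shown here, three measured steps bear on the change. The comparison of the two compounds without sulfo gives no change at the digits printed from compound 1 to compound 2 (within the scatter). Bringing in the sulfo-ended chain gives a 6.0-fold lower number from compound 1 to compound 3 (0.78 log units; beyond the scatter), and likewise a 6.0-fold lower number from compound 2 to compound 3 (0.78 log units; beyond the scatter). These last two steps are modest, and in this small set only compound 3, at 500 nM, stands apart. Removing sulfo is therefore expected to move the number in this assay upward, towards the level of compound 1 and compound 2, though not necessarily all the way. The expected step is a 3.0-fold higher number from compound 3 to compound 4 (0.48 log units; beyond the scatter). For compound 4 the estimated value is 1500 nM, with an expected range of 400 nM to 5000 nM.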

Compound 4, half-maximal inhibitory concentration: 700 nM
Estimate against measurement, compound 4: 2.1-fold (0.33 log units) above; the range from low to high includes it.
By their numbers in this assay, from the lowest: compounds 3 and 4 (each within the scatter of the next); then compounds 1 and 2 (each within the scatter of the next).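

In this assay, going by these compounds alone, replacing sulfo with dimethylamino at this chain position gives a 1.4-fold higher number from compound 3 to compound 4 (0.15 log units; within the scatter), so 3-sulfopropyl and 3-(dimethylamino)propyl are not told apart here, although sulfo alone had stood apart among the earlier compounds. The lower level is therefore not unique to sulfo, since the dimethylamino-ended chain also separates from the other two side chains, with a 4.3-fold lower number from compound 2 to compound 4 (0.63 log units; beyond the scatter) and a 4.3-fold lower number from compound 1 to compound 4 (0.63 log units; beyond the scatter), and the series now falls into two levels: the two compounds with these propyl chains, and the quinolin-2-ylmethyl and ethoxycarbonylmethyl compounds. Nothing among the data explains why two such different end groups sit at one level.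

The compounds shown leave open whether the propyl chain itself accounts for the lower level or whether an end group is needed, a question that a plain propyl chain or a 3-hydroxypropyl chain would address. They also leave open how a carboxylic acid or a primary amine at the chain end, or a longer chain carrying dimethylamino or sulfo, would compare with compound 3 and compound 4.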